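This account rests on a few compounds, and the source may have more. Where it says the series, first, only, none or still open, it means among the compounds named here.

Compound 1, whose structure is `CS(=O)(=O)CCCn1c(Cn2c(=O)n(C3CC3)c3ccncc32)nc2nc(Cl)ccc21`, is one of three compounds examined in an ADME assay on HeLa cells (Homo sapiens) for cytotoxicity, read by ATP content, with a stated time of 3 days; on this read-out higher numbers stand for lower toxicity in this test and lower numbers for higher toxicity in this test. In this assay compound 1 reaches only the limit of the assay, reported as > 50000 nM. Compound 2, with the structure `O=c1n(Cc2cc3cc(Br)ccc3n2CCCCO)c2cnccc2n1C1CC1`, gives in this assay a limit as well, > 50000 nM. Compound 3, `N#CCCCn1c(Cn2c(=O)n(-c3ccncc3F)c3ccncc32)cc2cc(Cl)ccc21`, likewise gives in this assay only the limit > 50000 nM. The picture is therefore (the limit of > 50000 nM in this assay, at which 3 of the 3 values shown sit), and no numbered value is available for compound 1 against which a step could be sized.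

Compound 4, with the structure `O=c1n(Cc2nc3nc(Cl)ccc3n2CCCCF)c2cnccc2n1C1CC1`, differs from compound 1 by the change (fluoromethyl in place of methylsulfonyl on a saturated chain carbon, three bonds along the chain from an aromatic nitrogen). Going by the values given here, no measured step of this kind exists among the three compounds. Given that compound 1 and both its companions sit at the limit, the step of a number no higher from compound 1 to compound 4 (the limit leaves the size open) is expected to be none beyond the scatter. Compound 4 is accordingly estimated to give in this assay about 50000 nM, within a range from 20000 nM to 100000 nM, most probably again reported only as a limit.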

Compound 4, half-maximal cytotoxic concentration: > 50000 nM
Compound 4: a limit, no number; the forecaster's own chance of this, stated with the estimate: 80%; the middle value sits exactly at the limit.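

Going by these compounds alone, compound 4, like compound 1, is reported in this assay only as a limit, so no step from compound 1 to compound 4 can be read. The compounds shown leave open at what concentration any of them would become cytotoxic in this assay and how they would rank, as all stand at one limit: the limit of > 50000 nM in this assay, at which 4 of the 4 values shown sit.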